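From difluorophenyl to methoxyphenyl on a shared core

The compounds below may be only part of what the source reports. "The series", "measured", "known", "first", "only" and "open" are said of these compounds alone.

- Compound 1 `COc1ccc(S(=O)(=O)N2CCc3cccc(-c4ccc(N)cc4)c32)cc1`: 249 nM
- Compound 2 `COc1ccc(S(=O)(=O)N2CCc3cccc(-c4ccc(F)c(F)c4)c32)cc1`: 45 nM
- Compound 3 `COc1ccc(S(=O)(=O)N2CCc3cccc(-c4cc(OC)c(OC)c(OC)c4)c32)cc1`: 3690 nM

All three values come from a functional assay on KB cells (Homo sapiens) for inhibition, with a stated time of 72 h; on this read-out higher numbers stand for weaker inhibition and lower numbers for stronger inhibition. Compound 2 has the lowest number of the three, so it is the strongest inhibitor measured so far. Compound 4 `COc1ccc(-c2cccc3c2N(S(=O)(=O)c2ccc(OC)cc2)CC3)cc1` keeps the shared core and changes only the group on the aromatic carbon: 4-methoxyphenyl in place of 3,4-difluorophenyl on an aromatic carbon.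

One measured step involves the same place and the same kind of swap: a 5.5-fold lower number from compound 1 to compound 2 (0.74 log units; beyond the scatter). It shows that exchanging this group can move the number beyond the scatter. Compound 3 also carries methoxy groups on the ring at this place, and its value of 3690 nM is far higher than that of compound 2. Going by the values given here, no measured compound has a lower number than compound 2, so a move toward a higher number is expected, of roughly the modest size seen before. The expected step is a 2.7-fold higher number from compound 2 to compound 4 (0.43 log units; beyond the scatter). Compound 4 is estimated at 120 nM, with an expected range from 25 nM to 600 nM.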

Compound 4, half-maximal inhibitory concentration: 337 nM
Compound 4: middle estimate off by 2.8-fold (0.45 log units), on the low side; low and high end bracket the measured number.
By their numbers in this assay, from the lowest: compound 2; then compounds 1 and 4 (each within the scatter of the next); then compound 3.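

Swapping 3,4-difluorophenyl for 4-methoxyphenyl on the same aromatic carbon in this assay gives a 7.5-fold higher number from compound 2 to compound 4 (0.87 log units; beyond the scatter), so this change is beyond the scatter and costs compound 2 its lead. Exchanging the group at the far end of the ring gives a different picture: methoxy in place of amino gives a 1.4-fold higher number from compound 1 to compound 4 (0.13 log units; within the scatter), which is within the scatter, so the two groups cannot be told apart in this read-out. Among the four compounds, the low number therefore belongs to the 3,4-difluorophenyl group alone, while the amino and methoxy compounds sit together at a clearly higher level.

No measurement here explains why these groups behave as they do. On these data alone, it also remains open whether one fluorine would be enough, as in a 4-fluorophenyl group, or how a ring carrying a nitrile or a carboxylic acid would compare.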